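Naphthyl amide on the hexafluoroisopropanol naphthol core

The source may hold more compounds than are shown below. What is called first, only, known or untested is meant among the compounds shown, and "the series" means these compounds.

Compound 1 `CCCNC(=O)COc1ccc2cc(C(O)(C(F)(F)F)C(F)(F)F)c(O)cc2c1`: > 20000 nM in an assay on isolated protein for inhibition of tyrosine-protein phosphatase non-receptor type 13 (Homo sapiens), read by spectrophotometry; on this read-out higher numbers stand for weaker inhibition and lower numbers for stronger inhibition (a limit)
Compound 2 `Oc1cc(-c2ccccc2)ccc1C(O)(C(F)(F)F)C(F)(F)F`: > 500000 nM in this assay (a limit)
Compound 3 `O=C(COc1ccc2cc(C(O)(C(F)(F)F)C(F)(F)F)c(O)cc2c1)N(c1ccccc1)c1ccccc1`: 12400 nM in this assay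

Compound 1 stands at a limit in this assay: for compound 1 the reading > 20000 nM is a limit, not a number, as the line the limit of > 20000 nM in this assay, at which 1 of the 3 values shown sits, records. Compound 2 likewise sits at a limit, (the limit of > 500000 nM in this assay, at which 1 of the 3 values shown sits), and the two limits tell nothing about how far apart the two compounds lie. Only compound 3 has a measured number, 12400 nM, and compound 3 carries two phenyl groups on the amide nitrogen where compound 1 carries the propyl chain.

Compound 4 `O=C(COc1ccc2cc(C(O)(C(F)(F)F)C(F)(F)F)c(O)cc2c1)Nc1cccc2ccccc12` is not yet measured. It differs from compound 1 by naphthalen-1-yl in place of propyl on an amide-type nitrogen. Among the compounds with values here, no step between measured compounds is available, so the expectation rests on the number for compound 3 and the limit for compound 1. Within the data shown here, an aromatic group on the amide nitrogen is the one feature shared by compound 3, the only compound with a number, so compound 4 is expected to give a measurable value, stronger than the limit of compound 1, with the expected step of an at least 1.3-fold lower number from compound 1 to compound 4 (0.12 log units; that floor lies within the scatter). The estimate for compound 4 is 15000 nM, within 5000 nM to 50000 nM.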

Compound 4, half-maximal inhibitory concentration: > 20000 nM
Compound 4: no number, only a limit; the forecaster's own chance of this, stated with the estimate: 35%; at least 1.3-fold (0.12 log units) between middle value and limit.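

Within the data shown here, compound 1 and compound 4 both stand at a limit in this assay, not at a number, so no step between them can be read: the limit of > 20000 nM in this assay, at which 2 of the 4 values shown sit.

The compounds shown leave open whether naphthalen-1-yl in place of propyl on an amide-type nitrogen changes inhibition at all.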